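Removing the chloro from compound 1: a step into the unknown

The source may report more compounds than this note shows. Statements on the series, on what has been measured and on what is new or still open speak of the compounds shown alone.

Among the compounds with values here, compound 1 `Cc1cc(O)c(C(C)C)cc1-c1cc(-c2ccccc2Cl)c(C#N)c(=O)[nH]1` sits at the bottom of the three numbers so far obtained in a functional assay for inhibition, tested at 80 ug/mL (on this read-out lower numbers stand for a weaker effect and higher numbers for a stronger effect at the one concentration tested), where compound 1 gives 32%. Within the data shown here, compound 3 `Cc1cc(O)c(C(C)C)cc1-c1cc(-c2ccc(N(C)C)cc2)c(C#N)c(=O)[nH]1` gives 66.5% in this assay, and compound 2 `COc1cc(-c2cc(-c3cc(C(C)C)c(O)cc3C)[nH]c(=O)c2C#N)cc(OC)c1OC` gives 82%; the step of a number 34.5 percentage points higher from compound 1 to compound 3 (beyond the scatter) lies beyond the scatter and is the only single-point change that has been measured. Compound 4 `Cc1cc(O)c(C(C)C)cc1-c1cc(-c2ccccc2)c(C#N)c(=O)[nH]1` differs from compound 1 by hydrogen in place of chloro on an aromatic carbon, a change placed ortho to a large group on the shared core. Among the measured compounds shown here, no measured step touches this change: the one step that exists swaps the whole 2-chlorophenyl for 4-(dimethylamino)phenyl, so it tells only that a different aryl can raise the read-out strongly, not what the chloro alone contributes. Compound 4 is therefore expected to show a number 13 percentage points higher from compound 1 to compound 4 (beyond the scatter) in this assay, a modest rise whose size is uncertain. The estimate for compound 4 is 45%, within 22% to 68%.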

Compound 4, a percentage reported as inhibition, at one concentration (the size of the read-out at that concentration, not a potency): 58%
For compound 4 the middle estimate is 13 percentage points below the measured one, within the range that was stated.
By their numbers in this assay, from the lowest: compound 1; then compounds 4 and 3 (each within the scatter of the next); then compound 2.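

In this assay the chloro alone carries weight: hydrogen in place of chloro on an aromatic carbon, ortho to a large group, gives a number 26 percentage points higher from compound 1 to compound 4 (beyond the scatter) and so separates this single atom from the swap of the whole aryl. Hydrogen in place of dimethylamino gives a number 8.5 percentage points lower from compound 3 to compound 4 (within the scatter) and so shows no readable contribution from the dimethylamino group, which means the large earlier step does not need that group to be explained. Nothing measured here says why the chloro has this effect.

As far as these compounds go, it remains open whether a fluoro, a methoxy or an amine at this place would read like the hydrogen or like the chloro. From the compounds shown here alone, whether a chloro elsewhere on the phenyl would carry the same cost also stays open.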